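The source may report more compounds than this note shows. Statements on the series, on what has been measured and on what is new or still open speak of the compounds shown alone.

Measured so far:
compound 1, `CC(C)c1nc2ccc(NC(=O)NCc3ccncc3)cn2n1`, 0%
compound 2, `O=C(NCc1cn[nH]c1)Nc1ccc2nc(-c3ccccc3)nn2c1`, 118%

Of the compounds shown here, two have been tested in an assay on HEK293-A cells for activation of Nicotinamide phosphoribosyltransferase (Homo sapiens), tested at 1 uM; a lower number here means a weaker effect, a higher number a stronger effect of the compound at the concentration tested. Compound 1, `CC(C)c1nc2ccc(NC(=O)NCc3ccncc3)cn2n1`, gives 0% in this assay. Compound 2, `O=C(NCc1cn[nH]c1)Nc1ccc2nc(-c3ccccc3)nn2c1`, gives 118%, and this is the higher of the two numbers; compound 1 lies far below it, a gap well beyond the usual scatter. Compound 1 and compound 2 differ in more than one place, so what the gap between them shows about any single change is not known.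

The next compound, compound 3, `O=C(NCc1cnco1)Nc1ccc2nc(-c3ccccc3)nn2c1`, has not yet been measured in this assay. It differs from compound 2 in one place: 1,3-oxazol-5-yl in place of 1H-pyrazol-4-yl on a saturated chain carbon bound to an amide-type nitrogen. The group that leaves carries one hydrogen-bond donor, the group that enters carries none, as counted above. Among the compounds with values here, no measured pair shows the effect of this exchange, so the size of the step can only be guessed. A decrease beyond the scatter is expected, with the step of a number 33 percentage points lower from compound 2 to compound 3 (beyond the scatter) from compound 2. Compound 3 is therefore estimated to give 85% in this assay, within a range from 30% to 125%.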

Compound 3, a percentage reported as activity, at one concentration (the size of the read-out at that concentration, not a potency): 103%
The estimate for compound 3 lay 18 percentage points below the measured number, and the stated range covers the measured number.
By their numbers in this assay, from the lowest: compound 1; then compound 3; then compound 2.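

In this assay the exchange of 1H-pyrazol-4-yl for 1,3-oxazol-5-yl on a saturated chain carbon bound to an amide-type nitrogen gives a number 15 percentage points lower from compound 2 to compound 3 (beyond the scatter) and so a modest loss beyond the scatter. Within the data shown here, this is the first single change that can be read at this position, and it shows that the read-out stays high without the hydrogen-bond donor of the 1H-pyrazol-4-yl group, as compound 3 has none and still gives 103% at the concentration tested. No measurement shown here bears on why the read-out moves with this exchange.

The compounds shown leave open how this position responds when the five-membered aromatic ring is replaced by something of another kind, such as a primary amine, a carboxylic acid or a phenyl ring, and whether a longer chain than the single carbon of the (1,3-oxazol-5-yl)methyl group would be accepted. Which of the several differences between compound 1 and compound 2 matters in this assay also remains unresolved, since no single change connects the two.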